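Aminocyclohexyl replacing methylaminopropyl in a bromo pyridine-fused amide series

This account rests on a few compounds, and the source may have more. Where it says the series, first, only, none or still open, it means among the compounds named here.

Measured in a functional assay on HCT-116 cells (Homo sapiens) for cytotoxicity, read by MTT assay, with a stated time of 72 h; a higher number here means a weaker inhibitor, a lower number a stronger inhibitor:
compound 1, `N[C@H]1CC[C@H](Nc2c(C(=O)NCc3ccc(F)cc3)nc(N3CCCCC3)c3cccnc23)CC1`, 8500 nM
compound 2, `Nc1ccc(Nc2c(C(=O)NCc3ccc(F)cc3)nc(Br)c3cccnc23)cc1`, 7000 nM
compound 3, `CNCCCNc1c(C(=O)NCc2ccc(F)cc2)nc(Br)c2cccnc12`, > 10000 nM

Compound 3 returns only a limit of this assay, > 10000 nM, so no number stands for it; it sits at the limit of > 10000 nM in this assay, at which 1 of the 3 values shown sits. Going by the values given here, the one step that reaches it, an at least 1.4-fold higher number from compound 2 to compound 3 (0.15 log units; that floor lies within the scatter), has a floor within the scatter and tells little about direction.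

Compound 4, `N[C@H]1CC[C@H](Nc2c(C(=O)NCc3ccc(F)cc3)nc(Br)c3cccnc23)CC1`, is not yet measured. It differs from compound 3 by 4-aminocyclohexyl in place of 3-(methylamino)propyl on a nitrogen on an aromatic ring.

The step from compound 3 to compound 4 cannot be sized from a measured pair, since compound 3 has no number. Compound 1, which also carries 4-aminocyclohexyl on a nitrogen on an aromatic ring, gives 8500 nM, and compound 2 gives 7000 nM. Both of these values lie near the upper end of what has been measured in this assay. Compound 4 is therefore expected to land in the same region, with the step of an at least 1.2-fold lower number from compound 3 to compound 4 (0.09 log units; that floor lies within the scatter) estimated as no more than modest. The estimate for compound 4 is 8000 nM, between 3500 nM and 18000 nM.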

Compound 4, half-maximal inhibitory concentration: 4000 nM
Compound 4: middle estimate off by 2.0-fold (0.30 log units), on the high side; low and high end bracket the measured number.
By their numbers in this assay, from the lowest: compounds 4, 2 and 1 (each within the scatter of the next, the first and the last beyond it). At a limit, above all of these: compound 3.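

In this assay, 4-aminocyclohexyl in place of 3-(methylamino)propyl on a nitrogen on an aromatic ring gives the first step at this position with a readable direction, an at least 2.5-fold lower number from compound 3 to compound 4 (0.39 log units; beyond the scatter), though its full size stays open, as compound 3 is only a limit: the limit of > 10000 nM in this assay, at which 1 of the 4 values shown sits.

Against 4-aminophenyl at the same place, the change separates nothing, a 1.8-fold lower number from compound 2 to compound 4 (0.24 log units; within the scatter), so these two groups stand level here. Going by these compounds alone, on an aromatic carbon, bromo in place of piperidin-1-yl gives the first reading of that site, a modest 2.1-fold lower number from compound 1 to compound 4 (0.33 log units; beyond the scatter).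

Open, from the compounds shown here alone, is whether the step from compound 3 follows the ring or the methyl on the chain's amine, which 3-aminopropyl would separate. Also open, going by these compounds, is how a morpholin-4-yl or a methoxy group on that aromatic carbon would read in this assay.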